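Replacing Formyl with 2-Hydroxyethyl on an Amine Nitrogen

A few compounds are considered here, and "the series" means these few. Any claim that something is new, unique, unknown or untested is made for them only; others in the source may bear on it.

In an ADME assay on Caco-2 cells (Homo sapiens) for permeability, in the apical to basolateral direction (on this read-out lower numbers stand for lower permeability and higher numbers for higher permeability), compound 3 `Cn1nc2c(=O)n(CC3(O)CCN(Cc4ccc(-c5ccco5)cc4Cl)CC3)cnc2c1-c1ccc(CNC=O)cc1` gives 0.65 10^-6 cm/s. Compound 2 `Cn1nc2c(=O)n(CC3(O)CCN(Cc4ccc(-c5cnco5)cc4Cl)CC3)cnc2c1-c1ccc(CN)cc1` gives 0.86 10^-6 cm/s, within the scatter of compound 3, while compound 1 `Cn1nc2c(=O)n(CC3(O)CCN(Cc4ccc(-c5ccco5)cc4Cl)CC3)cnc2c1-c1ccc(C2(N)CC2)cc1` gives 1.99 10^-6 cm/s. For the measured compounds named here, the one measured step that differs in a single place is a 3.1-fold lower number from compound 1 to compound 3 (0.49 log units; beyond the scatter), a modest change beyond the scatter, with (formylamino)methyl in place of 1-aminocyclopropyl on an aromatic carbon.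

Compound 4 `Cn1nc2c(=O)n(CC3(O)CCN(Cc4ccc(-c5ccco5)cc4Cl)CC3)cnc2c1-c1ccc(CNCCO)cc1` differs from compound 3 by 2-hydroxyethyl in place of formyl on an amine nitrogen. Going by the values given here, no measured step makes this exact exchange, and the step above bears on it only loosely, since its incoming group is a different one. Compound 4 shares with compound 2, at 0.86 10^-6 cm/s, and with compound 1, at 1.99 10^-6 cm/s, the absence of a formyl group, although neither carries 2-hydroxyethyl. A small upward move in this assay is therefore expected, one that stays within the scatter, and the estimated step is a 1.4-fold higher number from compound 3 to compound 4 (0.14 log units; within the scatter). For compound 4 the expected value is 0.9 10^-6 cm/s, with an estimated range from 0.4 10^-6 cm/s to 2 10^-6 cm/s.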

Compound 4, apparent permeability: 0.36 10^-6 cm/s
Estimate against measurement, compound 4: 2.5-fold (0.40 log units) above, outside the stated range (below it).
By their numbers in this assay, from the lowest: compounds 4, 3 and 2 (each within the scatter of the next, the first and the last beyond it); then compound 1.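

Placed on the amine nitrogen, 2-hydroxyethyl brings a hydrogen-bond donor where formyl brings none, and this exchange gives a 1.8-fold lower number from compound 3 to compound 4 (0.26 log units; within the scatter), so this assay does not separate these two substituents at this position. For the compounds shown here, the wider step, a 5.5-fold lower number from compound 1 to compound 4 (0.74 log units; beyond the scatter), lies beyond the scatter and, read with a 3.1-fold lower number from compound 1 to compound 3 (0.49 log units; beyond the scatter), places compound 1 with its 1-aminocyclopropyl group above both ((2-hydroxyethyl)amino)methyl and (formylamino)methyl, a relation that the earlier compounds showed for only one of these groups. Nothing available gives a measured reason for these differences.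

From the compounds shown here alone, it remains open whether an acetyl group, a methyl group or a longer chain such as 3-hydroxypropyl on the same amine nitrogen would also stay within the scatter of compound 3. Going by these compounds, it is also open whether the distance from compound 1 follows from the cyclopropane ring itself or from the substituent on the nitrogen, a question that a 1-aminocyclopropyl group carrying 2-hydroxyethyl or formyl on its amine could address.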